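A few compounds are considered here, and "the series" means these few. Any claim that something is new, unique, unknown or untested is made for them only; others in the source may bear on it.

Measured so far in a functional assay on PC-3 cells (Homo sapiens) for inhibition, read by MTT assay, with a stated time of 48 h; on this read-out lower numbers stand for stronger inhibition and higher numbers for weaker inhibition:
- compound 1 `COc1cc(N(Cc2ccc(F)cc2)S(=O)(=O)c2ccc(C)cc2)cc(OC)c1OC`: 20700 nM
- compound 2 `COc1cc(N(Cc2ccc(Br)cc2)S(=O)(=O)c2ccc(C)cc2)cc(OC)c1OC`: 4680 nM
- compound 3 `COc1cc(N(Cc2nc3ccccc3[nH]2)S(=O)(=O)c2ccc(F)cc2)cc(OC)c1OC`: 7990 nM

Within the data shown here, compounds 1 and 2 share a core; the step of a 4.4-fold lower number from compound 1 to compound 2 (0.65 log units; beyond the scatter) is the only single-point change measured so far, and it is the change (bromo in place of fluoro on an aromatic carbon). The difference between the core of compound 3 and that of compound 1 is not broken down here. Compound 3 and compound 2 lie within the scatter of each other in this assay; compound 3 sits beyond the scatter below compound 1.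

Compound 4 `COc1cc(N(Cc2nc3ccccc3[nH]2)S(=O)(=O)c2ccc(Br)cc2)cc(OC)c1OC` is not yet measured. It differs from compound 3 by bromo in place of fluoro on an aromatic carbon, the same change as before at the same kind of place, though cut one bond further out it reads (4-fluorophenyl)sulfonyl to (4-bromophenyl)sulfonyl rather than 4-fluorobenzyl to 4-bromobenzyl. Among the measured compounds shown here, a step in the same direction but of less certain size is expected, a 2.7-fold lower number from compound 3 to compound 4 (0.43 log units; beyond the scatter), resting on the single precedent a 4.4-fold lower number from compound 1 to compound 2 (0.65 log units; beyond the scatter). Compound 4 is expected at about 3000 nM, within 1200 nM to 8000 nM.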

Compound 4, half-maximal inhibitory concentration: 6890 nM
Estimate against measurement, compound 4: 2.3-fold (0.36 log units) below; the measured number falls inside the stated range.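

In this assay, bromo in place of fluoro gives a 1.2-fold lower number from compound 3 to compound 4 (0.06 log units; within the scatter), so the change does not separate these two compounds on this core. Its size does not carry over between the two cores: the same change on two cores in this assay, a 4.4-fold lower number (0.65 log units; beyond the scatter) from compound 1 to compound 2 and a 1.2-fold lower number (0.06 log units; within the scatter) from compound 3 to compound 4, 3.8-fold (0.58 log units) apart, beyond the scatter of two such steps This shows that the earlier step is a poor guide to the size of the change on the other core, but two pairs do not show what sets the gap, and the change sits on a benzyl group in one pair and on a phenylsulfonyl group in the other.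

Going by these compounds, whether chloro, nitrile or an amine in the same place would separate from fluoro on either core remains open. Also open, on these data alone, is whether such groups would follow the same order on both cores.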